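Swapping a nitrile for an amine on an indole side chain

The compounds below may be only part of what the source reports. "The series", "measured", "known", "first", "only" and "open" are said of these compounds alone.

Measured compounds:
Compound 1 `N#CCCCc1c[nH]c2ccc(F)cc12` — 63 nM
Compound 2 `N#CCCCc1c[nH]c2ccc(C(=O)O)cc12` — "not active" (no number reported)

Two compounds share a core that carries a short saturated chain ending in a cyano group. In an assay on isolated protein (urine) for inhibition of Myeloperoxidase (Homo sapiens), with a stated time of 5 min (on this read-out higher numbers stand for weaker inhibition and lower numbers for stronger inhibition), compound 1 gives 63 nM. Where compound 1 carries a fluorine on the core, compound 2 carries a carboxylic acid; in this assay compound 2 gives "not active" (no number reported), so no number stands for it, and the pair can only be read as one active and one inactive compound.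

Compound 3 `NCCCCc1c[nH]c2ccc(C(=O)O)cc12` has not been measured. It keeps the carboxylic acid of compound 2 and differs from it in one place: aminomethyl in place of cyano on a saturated chain carbon, three bonds along the chain from an aromatic carbon. Going by the values given here, no measured pair shows what this exchange does in this assay, so the size and direction of the step are open. With compound 2 reported as inactive, the expectation for compound 3 is a weak result, with a real chance that this assay again reports no number.

The potency of compound 3 in this assay is estimated at 30000 nM, with a range from 3000 nM to 300000 nM.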

Compound 3, half-maximal inhibitory concentration: "not active" (no number reported)
For compound 3 the study gives words and no number, so the estimate cannot be set against anything.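

In this assay compound 2 and compound 3 are both reported as "not active" with no number, so no step can be read from the change from cyano to aminomethyl. From the compounds shown here alone, what this exchange does on a core carrying fluorine, as in compound 1, stays open. Nothing shown here offers an explanation for the result.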